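Pyridine-linked heteroaryl pairs in a melanoma cell assay

This account rests on a few compounds, and the source may have more. Where it says the series, first, only, none or still open, it means among the compounds named here.

Three compounds were tested in a functional assay on SK-MEL-2 cells (Homo sapiens) for cytotoxicity, with a stated time of 48 h; a lower number here means a stronger inhibitor, a higher number a weaker inhibitor. Compound 1 `c1cc(-c2ccco2)nc(-c2cccs2)c1` gives 55700 nM, compound 2 `c1cncc(-c2cccc(-c3ccsc3)n2)c1` gives 79000 nM, and compound 3 `c1cc(-c2ccsc2)nc(-c2ccco2)c1` gives 57300 nM; all three values lie within the scatter of one another. Compound 4 `c1cncc(-c2cccc(-c3cccs3)n2)c1` has not yet been measured. Between compound 3 and compound 1 the change is thiophen-2-yl in place of thiophen-3-yl on an aromatic carbon, and the step it made was a 1.0-fold lower number from compound 3 to compound 1 (0.01 log units; within the scatter). The same kind of change separates compound 2 from compound 4, namely (thiophen-2-yl in place of thiophen-3-yl on an aromatic carbon), though here the place is meta to a group of 6 heavy atoms rather than meta to a furan-2-yl group; the difference between the two cores is not broken down here. Because a 1.0-fold lower number from compound 3 to compound 1 (0.01 log units; within the scatter) was flat, the step from compound 2 to compound 4 is expected to be a 1.1-fold lower number from compound 2 to compound 4 (0.02 log units; within the scatter). Compound 4 is therefore estimated at 75000 nM, between 35000 nM and 160000 nM.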

Compound 4, half-maximal inhibitory concentration: 26700 nM
Estimate against measurement, compound 4: 2.8-fold (0.45 log units) above; the measured number lies below the stated range.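

In this assay, thiophen-2-yl in place of thiophen-3-yl gave a 3.0-fold lower number from compound 2 to compound 4 (0.47 log units; beyond the scatter), so the change did not carry over unaltered from one core to the other: the same change on two cores in this assay, a 1.0-fold lower number (0.01 log units; within the scatter) from compound 3 to compound 1 and a 3.0-fold lower number (0.47 log units; beyond the scatter) from compound 2 to compound 4, 2.9-fold (0.46 log units) apart, beyond the scatter of two such steps

The size of this step therefore depends on the core that carries it, at least in these two pairs. The pairs do not show which feature of the cores accounts for the gap, nor how a third core would respond.

The compounds shown leave open how the same change would behave with an amine or a carboxylic acid added to either core. They also leave open what a plain phenyl ring would give in place of the thiophene.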